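From 2,5-dimethylphenyl to 3-fluorophenyl on the ring nitrogen

This account rests on a few compounds, and the source may have more. Where it says the series, first, only, none or still open, it means among the compounds named here.

In a toxicity assay on HUVEC cells (Homo sapiens) for inhibition (on this read-out lower numbers stand for stronger inhibition of growth and higher numbers for weaker inhibition of growth), compound 1 (`Cc1ccc(C)c(N2CCN(C(=O)c3oc(C)nc3-c3ccccc3)CC2)c1`) gives 1.73 ug/mL and stands highest of the three numbers, beyond the scatter from the other two. Those are compound 2 (`Cc1nc(-c2cccc(F)c2)c(C(=O)N2CCN(c3cc(Cl)cc(Cl)c3)CC2)o1`) at 0.134 ug/mL and compound 3 (`COc1cc(OC)cc(N2CCN(C(=O)c3oc(C)nc3-c3cccc(F)c3)CC2)c1`) at 0.126 ug/mL in the same read-out. Compound 4 (`Cc1nc(-c2ccccc2)c(C(=O)N2CCN(c3cccc(F)c3)CC2)o1`) has not yet been measured and differs from compound 1 at one place (3-fluorophenyl in place of 2,5-dimethylphenyl on an amine nitrogen in a ring), with 3-fluorophenyl in place of 2,5-dimethylphenyl on an amine nitrogen in a ring. Within the data shown here, the only measured step at that place, a 1.1-fold lower number from compound 2 to compound 3 (0.03 log units; within the scatter), stays within the scatter, but it does not start from 2,5-dimethylphenyl, so no measured step gives this change directly. Compound 3 at 0.126 ug/mL points the expectation downward, and the rest of compound 1 stays in compound 4, so only part of that gap is expected to be closed. An estimated 3.5-fold lower number from compound 1 to compound 4 (0.54 log units; beyond the scatter) is therefore expected, with wide uncertainty. For compound 4 the estimated value is 0.5 ug/mL (expected range 0.12 ug/mL to 2 ug/mL) in this assay once it is tested.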

Compound 4, concentration for 50% growth inhibition: 1.05 ug/mL
Estimate against measurement, compound 4: 2.1-fold (0.32 log units) below, and the stated range covers the measured number.
By their numbers in this assay, from the lowest: compounds 3 and 2 (each within the scatter of the next); then compounds 4 and 1 (each within the scatter of the next).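

In this assay, replacing 2,5-dimethylphenyl with 3-fluorophenyl on the amine nitrogen in the ring gives a 1.6-fold lower number from compound 1 to compound 4 (0.22 log units; within the scatter), the first step shown that starts from 2,5-dimethylphenyl. Beside a 1.1-fold lower number from compound 2 to compound 3 (0.03 log units; within the scatter), it makes two steps at this place, on different remainders of the molecule, and neither separates its two compounds, although each exchanges one aromatic carbon ring for another. Nothing available explains this result.

No pair shown differs only in the phenyl group on the core of compound 4 and the 3-fluorophenyl group on the core of compound 3, so it remains open which change accounts for the gap between these compounds. Also open, going by these compounds, is how this assay would read with a non-aromatic group on the ring nitrogen, such as a cyclohexyl group or a longer alkyl chain.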